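Methyl next to the ring nitrogen: an expected small shift

A few compounds are considered here, and "the series" means these few. Any claim that something is new, unique, unknown or untested is made for them only; others in the source may bear on it.

Measured so far:
Compound 1, `Cc1cccc(C)c1-c1cccc(COc2ccc(CCC(=O)O)cc2)c1`: 6.7 nM
Compound 2, `Cc1cccc(C)c1-c1cccc(COc2ccc(CCC(=O)O)cn2)c1`: 3.5 nM
Compound 3, `Cc1cc(OCc2cccc(-c3c(C)cccc3C)c2)ncc1CCC(=O)O`: 9.3 nM

In a functional assay on CHO cells for agonist activity at Free fatty acid receptor 1 (Homo sapiens), read by calcium flux (on this read-out lower numbers stand for an effect already at smaller amounts and higher numbers for an effect only at larger amounts of compound), compound 2 gives the lowest of the three numbers. Compound 1, with 6.7 nM, lies within the scatter of compound 2, so the two cannot be told apart. Compound 3 stands further away: the step of a 2.7-fold higher number from compound 2 to compound 3 (0.42 log units; beyond the scatter) is beyond the scatter.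

Compound 4, `Cc1cccc(C)c1-c1cccc(COc2ccc(CCC(=O)O)c(C)n2)c1`, has not yet been measured. It differs from compound 2 in one place: methyl in place of hydrogen on an aromatic carbon. For the measured compounds named here, only one measured step bears on this kind of change, the step from compound 2 to compound 3, which also replaced a hydrogen with a methyl on an aromatic carbon, though at a different spot, and gave a 2.7-fold higher number from compound 2 to compound 3 (0.42 log units; beyond the scatter). On that basis a modest rise of similar size is expected for compound 4, estimated as a 2.3-fold higher number from compound 2 to compound 4 (0.36 log units; beyond the scatter) in this assay. Compound 4 is therefore expected at about 8 nM, with a range from 3 nM to 22 nM, a result that could still fall within the scatter of compound 2.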

Compound 4, half-maximal effective concentration: 81 nM
Estimate against measurement, compound 4: 10-fold (1.01 log units) below; the whole stated range lies below it.
By their numbers in this assay, from the lowest: compounds 2, 1 and 3 (each within the scatter of the next, the first and the last beyond it); then compound 4.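

In this assay, a single methyl on the aromatic carbon next to the ring nitrogen and ortho to a 2-carboxyethyl group gives a 23-fold higher number from compound 2 to compound 4 (1.36 log units; beyond the scatter), which is a large step. The same exchange of hydrogen for methyl on another aromatic carbon gave only a 2.7-fold higher number from compound 2 to compound 3 (0.42 log units; beyond the scatter), so in these two compounds the outcome depends strongly on where the methyl sits. Nothing available here accounts for the difference between the two spots.

The compounds shown leave open whether a fluorine atom, a methoxy group or an ethyl group on this carbon would raise the number as much as methyl does. They also leave open whether a methyl at the matching carbon of compound 1, whose ring lacks the nitrogen, would produce a similar step.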